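Nitro in Place of Trifluoromethyl on the Aryl Ring

This account rests on a few compounds, and the source may have more. Where it says the series, first, only, none or still open, it means among the compounds named here.

Three measured compounds share one core and differ only in the group on the six-membered carbon ring. Compound 1 `CSc1cccc(N2CCN(Cc3nc[nH]c3C)C2=O)c1` gives 120 nM in a functional assay (Cavia porcellus) for antagonist activity at Serotonin 3 (5-HT3) receptor (Homo sapiens); on this read-out higher numbers stand for weaker inhibition and lower numbers for stronger inhibition. Compound 2 `Cc1cccc(N2CCN(Cc3nc[nH]c3C)C2=O)c1` gives 45.7 nM in this assay, and compound 3 `Cc1[nH]cnc1CN1CCN(c2cccc(C(F)(F)F)c2)C1=O` gives 68.5 nM. Compound 3 thus stands second highest of the three numbers: its nearest neighbour is compound 2, with a 1.5-fold higher number from compound 2 to compound 3 (0.18 log units; within the scatter), and its furthest is compound 1, with a 1.8-fold lower number from compound 1 to compound 3 (0.24 log units; within the scatter). The only step beyond the scatter among these three is a 2.6-fold lower number from compound 1 to compound 2 (0.42 log units; beyond the scatter).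

Compound 4 `Cc1[nH]cnc1CN1CCN(c2cccc([N+](=O)[O-])c2)C1=O` differs from compound 3 by nitro in place of trifluoromethyl on an aromatic carbon. Within the data shown here, no measured step introduces a nitro group, so the bearing steps are only the three above, all modest or within the scatter, which suggests that exchanging one small group for another on this ring moves the number little. Compound 4 is therefore expected to show a 1.0-fold higher number from compound 3 to compound 4 (0.01 log units; within the scatter), no step beyond the scatter. The estimate for compound 4 in this assay is 70 nM, within a range from 25 nM to 200 nM.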

Compound 4, antagonist equilibrium constant: 125 nM
For compound 4 the middle estimate is 1.8-fold (0.25 log units) below the measured one, and the stated range covers the measured number.
By their numbers in this assay, from the lowest: compounds 2, 3, 1 and 4 (each within the scatter of the next, the first and the last beyond it).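

In this assay nitro does not separate from trifluoromethyl, with a 1.8-fold higher number from compound 3 to compound 4 (0.26 log units; within the scatter), or from methylsulfanyl, with a 1.0-fold higher number from compound 1 to compound 4 (0.02 log units; within the scatter), but it does separate from methyl, with a 2.7-fold higher number from compound 2 to compound 4 (0.44 log units; beyond the scatter). Methyl now stands beyond the scatter from two of the three other groups at this aromatic carbon, while trifluoromethyl, which lies within the scatter of all three, stands beyond it from none, so the four groups span only a modest range in which methyl gives the lowest number. No measured property of these groups is available to account for these steps.

The compounds shown leave open how an amine, a carboxylic acid or a longer alkyl chain would read on this aromatic carbon. They also leave open whether the step from methyl to nitro would keep its size with either group elsewhere on the six-membered ring.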